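The source may report more compounds than this note shows. Statements on the series, on what has been measured and on what is new or still open speak of the compounds shown alone.

The measured compounds:
Compound 1 `O=C(COc1ccc2cc(C(O)(C(F)(F)F)C(F)(F)F)c(O)cc2c1)Nc1ccccc1` gives in an assay on isolated protein for inhibition of receptor-type tyrosine-protein phosphatase C (Homo sapiens), read by spectrophotometry (on this read-out lower numbers stand for stronger inhibition and higher numbers for weaker inhibition), a value that is a limit of the assay, > 20000 nM.
Compound 2 `COc1ccc(CNC(=O)COc2ccc3cc(C(O)(C(F)(F)F)C(F)(F)F)c(O)cc3c2)cc1OC` also gives in this assay only a limit, > 20000 nM.
Compound 3 `Cc1ccc(S(=O)(=O)NNC(=O)COc2ccc3cc(C(O)(C(F)(F)F)C(F)(F)F)c(O)cc3c2)cc1` gives in this assay 16100 nM.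

Compound 1 thus stands at a limit of this assay, and the account of the measured values notes (the limit of > 20000 nM in this assay, at which 2 of the 3 values shown sit). The compound not yet measured, compound 4 `O=C(COc1ccc2cc(C(O)(C(F)(F)F)C(F)(F)F)c(O)cc2c1)N(c1ccccc1)c1ccccc1`, differs from compound 1 in one place: phenyl in place of hydrogen on an amide-type nitrogen. All three measured steps change the group on the amide-type nitrogen and so bear on this one. The step that the two limits leave unreadable from compound 1 to compound 2 cannot be read. The step of an at least 1.2-fold lower number from compound 1 to compound 3 (0.09 log units; that floor lies within the scatter) and the step of an at least 1.2-fold lower number from compound 2 to compound 3 (0.09 log units; that floor lies within the scatter) each give only a floor that lies within the scatter. None of these steps shows a change on the amide-type nitrogen moving the number beyond the scatter. The step that the limit leaves unreadable from compound 1 to compound 4 is therefore expected to be none beyond the scatter, with a limit again the most likely report. Compound 4 is estimated at 25000 nM, with a range from 8000 nM to 80000 nM.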

Compound 4, half-maximal inhibitory concentration: 14900 nM
Compound 4: the middle estimate sits 1.7-fold (0.22 log units) above what was measured, within the range that was stated.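

With phenyl in place of hydrogen on the amide-type nitrogen, compound 4 gives a readable number in this assay, 14900 nM, so this nitrogen can lose the amide hydrogen and carry a second phenyl while the inhibition remains measurable. Compound 1 gives only a limit, > 20000 nM. The change can therefore be stated only as an at least 1.3-fold lower number from compound 1 to compound 4 (0.12 log units; that floor lies within the scatter), which shows no move beyond the scatter, and limits still account for part of the values: the limit of > 20000 nM in this assay, at which 2 of the 4 values shown sit.

The compounds shown leave open whether a methyl on this nitrogen in place of the amide hydrogen would give a readable number as well. They also leave open whether an amine or a carboxylic acid on the added phenyl would move the number beyond the scatter.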